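The source may report more compounds than this note shows. Statements on the series, on what has been measured and on what is new or still open speak of the compounds shown alone.

Measured in a functional assay on SNB-19 cells (Homo sapiens) for inhibition, read by sulforhodamine B assay, with a stated time of 48 h, tested at 10 uM; on this read-out lower numbers stand for less inhibition and higher numbers for more inhibition at the one concentration tested (going by the name of the read-out):
compound 1 `c1ccc2c(-c3cn4ccnc4c(-c4ccc5ncn(C6CCCCC6)c5c4)n3)cccc2c1`: 9.08%
compound 2 `c1ccc(Cn2cnc3ccc(-c4nc(-c5cccc6ccccc56)cn5ccnc45)cc32)cc1`: 5.12%
compound 3 `c1cn2cc(-c3ccc4c(c3)ncn4C3CCCCC3)nc(-c3ccc4ncn(C5CCCCC5)c4c3)c2n1`: 10.6%

Compound 2 arises from compound 1 by benzyl in place of cyclohexyl on an aromatic nitrogen; in this assay the step is a number 4 percentage points lower from compound 1 to compound 2 (within the scatter). The difference between the core of compound 1 and the core of compound 3 is not broken down here. Compound 3 shows 10.6% in this assay, and all three numbers sit within the scatter of one another, so no order among them is drawn.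

Compound 4 `c1ccc(Cn2cnc3ccc(-c4nc(-c5ccc6c(c5)ncn6C5CCCCC5)cn5ccnc45)cc32)cc1` is not yet measured. It arises from compound 3 by benzyl in place of cyclohexyl on an aromatic nitrogen, the same change as between compound 1 and compound 2, at the same place. The step is expected to be a number 3.6 percentage points lower from compound 3 to compound 4 (within the scatter), which rests on the earlier pair, because a number 4 percentage points lower from compound 1 to compound 2 (within the scatter) gave only a small shift. Compound 4 is therefore estimated at 7%, with a range from 0% to 16%.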

Compound 4, a percentage reported as inhibition, at one concentration (the size of the read-out at that concentration, not a potency): 80.4%
Estimate against measurement, compound 4: 73.4 percentage points below; measured number above the stated range.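

In this assay, benzyl in place of cyclohexyl on an aromatic nitrogen gives a number 69.8 percentage points higher from compound 3 to compound 4 (beyond the scatter), and the step does not carry over between the two cores: the same change on two cores in this assay, a number 4 percentage points lower (within the scatter) from compound 1 to compound 2 and a number 69.8 percentage points higher (beyond the scatter) from compound 3 to compound 4, 73.8 percentage points apart, beyond the scatter of two such steps.
The size of this change therefore depends on the core it sits on, and the step on one core cannot stand in for the step on the other.
Two pairs do not show which part of the core of compound 3 makes the difference, nor which step a third core would follow.

Open, as far as these compounds go, is whether the benzyl ring itself is needed, or whether a phenethyl chain or an aminoethyl chain on that nitrogen would give a similar number. Also open, from the compounds shown here alone, is how compound 4 behaves at other concentrations, as one concentration gives no potency.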